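A few compounds are considered here, and "the series" means these few. Any claim that something is new, unique, unknown or untested is made for them only; others in the source may bear on it.

Going by the values given here, the three compounds measured so far share one core and differ only in the amino-acid-derived piece attached to it. Compound 1 `CC[C@H](C)[C@H](NC(=O)CN(c1nc(Cl)nc2[nH]cnc12)C1CC1)C(=O)O` is the starting point here; in a functional assay on the whole organism (Tail, strain ICR) with Mus musculus as the target, in the tail flick test, with a stated time of 90 min, at a dose of 25 umol/kg by the oral route (a higher number here means a stronger effect of the compound at the dose given, a lower number a weaker effect), compound 1 gives 27.4%. Compound 2 `O=C(OCc1ccccc1)[C@@H]1CCCN1C(=O)CN(c1nc(Cl)nc2[nH]cnc12)C1CC1` gives 43.3% in this assay, and compound 3 `NCCCC[C@H](NC(=O)CN(c1nc(Cl)nc2[nH]cnc12)C1CC1)C(=O)OCc1ccccc1` gives 35.3% in this assay. Compound 1 thus has the smallest of the three numbers, but the gap to compound 3 lies within the usual scatter of repeated measurements, whereas the gap to compound 2 lies beyond it.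

Compound 4 `C[C@@H](O)[C@H](NC(=O)CN(c1nc(Cl)nc2[nH]cnc12)C1CC1)C(=O)O` keeps everything of compound 1 except one spot on the side chain: hydroxy in place of ethyl on a saturated chain carbon bound to two saturated chain carbons. Among the compounds with values here, no measured pair shows what this kind of change does, so the expectation rests on compound 1 alone. Compound 4 is expected to stay close to compound 1, with an expected step of a number 2.4 percentage points lower from compound 1 to compound 4 (within the scatter), a change not beyond the scatter. The estimate for compound 4 is 25%, with a likely range from 10% to 40%.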

Compound 4, a percentage reported as activity, at one dose (the size of the read-out at that dose, not a potency): 35.9%
Compound 4: the middle estimate sits 10.9 percentage points below what was measured; the measured number falls inside the stated range.
By their numbers in this assay, from the lowest: compounds 1, 3, 4 and 2 (each within the scatter of the next, the first and the last beyond it).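

Going by these compounds alone, compound 1 and compound 4 form the first pair that differs in one place, so they give the first direct reading of this position. In this assay, hydroxy in place of ethyl on a saturated chain carbon bound to two saturated chain carbons gives a number 8.5 percentage points higher from compound 1 to compound 4 (within the scatter). This position therefore accepts a single oxygen-bearing hydroxy, with its hydrogen-bond donor and acceptor, in place of the two-carbon ethyl without a step beyond the scatter, and no measurement at hand explains this result.

Still open, as far as these compounds go, is whether a methoxy group or an amine on this same carbon would also stay within the scatter of compound 1. Also open, from the compounds shown here alone, is whether the same swap would give a similar step in a compound carrying a benzyl ester instead of the free carboxylic acid.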